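This account rests on a few compounds, and the source may have more. Where it says the series, first, only, none or still open, it means among the compounds named here.

Compound 2 `Nc1scc(CN2CCN(c3ccc(Cl)c(C(F)(F)F)c3)CC2)c1C(=O)c1ccc(Cl)cc1` and compound 1 `Nc1scc(CN2CCN(c3ccc([N+](=O)[O-])cc3)CC2)c1C(=O)c1ccc(Cl)cc1` share one core and differ only in the group on an amine nitrogen in a ring. In a functional assay on CHO cells with adenosine receptor A1 (Homo sapiens) as the target, read by cAMP accumulation and immunoassay, with a stated time of 6 min, tested at 0.1 uM (on this read-out lower numbers stand for a stronger effect and higher numbers for a weaker effect at the one concentration tested), compound 2 gives -12%, and compound 1 gives -13%; the two lie within the scatter of each other. Compound 3 `Nc1scc(CN2CCN(c3cccnc3)CC2)c1C(=O)c1ccc(Cl)cc1` carries pyridin-3-yl in place of 4-chloro-3-(trifluoromethyl)phenyl on an amine nitrogen in a ring. Going by the values given here, the single measured step, a number 1 percentage points higher from compound 1 to compound 2 (within the scatter), exchanges a different group at that place and stays within the scatter, so no measured step speaks directly to a pyridin-3-yl there. The step of a number 2 percentage points higher from compound 2 to compound 3 (within the scatter) is therefore expected to stay within the scatter. Compound 3 is estimated at -10%, between -25% and 6%.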

Compound 3, a percentage reported as activity, at one concentration (the size of the read-out at that concentration, not a potency): 3.4%
The estimate for compound 3 lay 13.4 percentage points below the measured number, within the range that was stated.
By their numbers in this assay, from the lowest: compounds 1 and 2 (each within the scatter of the next); then compound 3.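

In this assay, the group on the ring amine nitrogen can move the read-out: replacing either substituted phenyl with pyridin-3-yl gives a number 15.4 percentage points higher from compound 2 to compound 3 (beyond the scatter) and a number 16.4 percentage points higher from compound 1 to compound 3 (beyond the scatter), both toward a weaker effect at the one concentration tested. The earlier exchange between two substituted phenyl groups had shown no step beyond the scatter. No measured evidence accounts for this shift. Going by these compounds, each step changes both the ring and its substituents, so which change matters remains open. A plain phenyl group at this position could separate the two.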